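This account rests on a few compounds, and the source may have more. Where it says the series, first, only, none or still open, it means among the compounds named here.

Of the compounds shown here, three of a shared core have been measured in a functional assay on MCF7 cells (Homo sapiens) for antiproliferative activity, read by sulforhodamine B assay, with a stated time of 48 h; a lower number here means a stronger inhibitor, a higher number a weaker inhibitor. Compound 1, `CC(C)c1ccccc1OS(=O)(=O)c1ccc(NC(=O)CCCl)cc1`, gives 9000 nM in this assay. Compound 2, `O=C(CCCl)Nc1ccc(S(=O)(=O)Oc2ccccc2I)cc1`, differs from compound 1 by iodo in place of isopropyl on an aromatic carbon. In this assay compound 2 gives 8900 nM, so that the step is a 1.0-fold lower number from compound 1 to compound 2 (0.00 log units; within the scatter). Compound 3, `CCNC(=O)Nc1ccc(S(=O)(=O)Oc2ccccc2C(C)C)cc1`, differs from compound 1 in its core by ethylamino in place of 2-chloroethyl on a carbonyl carbon. In this assay compound 3 gives 10000 nM, a step of a 1.1-fold higher number from compound 1 to compound 3 (0.05 log units; within the scatter). The three values thus sit close together, none of them separated from another beyond the scatter.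

Compound 4, `CCNC(=O)Nc1ccc(S(=O)(=O)Oc2ccccc2I)cc1`, has not yet been measured. It differs from compound 3 by iodo in place of isopropyl on an aromatic carbon, the same change that turns compound 1 into compound 2, here made on the core of compound 3 rather than on the core of compound 1. That earlier change produced a step of a 1.0-fold lower number from compound 1 to compound 2 (0.00 log units; within the scatter). Since the earlier step of a 1.0-fold lower number from compound 1 to compound 2 (0.00 log units; within the scatter) lies within the scatter, the step is expected to be no change at the digits printed from compound 3 to compound 4 (within the scatter). Compound 4 is therefore expected to give about 10000 nM in this assay, estimated to fall between 5000 nM and 20000 nM.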

Compound 4, half-maximal inhibitory concentration: 1100 nM
Compound 4: middle estimate off by 9.1-fold (0.96 log units), on the high side; measured number outside the range, below it.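

In this assay, iodo in place of isopropyl on an aromatic carbon gives a 9.1-fold lower number from compound 3 to compound 4 (0.96 log units; beyond the scatter), whereas the same change left the number unmoved on the core that carries the 2-chloroethyl group, so it does not carry from one core to the other: the same change on two cores in this assay, a 1.0-fold lower number (0.00 log units; within the scatter) from compound 1 to compound 2 and a 9.1-fold lower number (0.96 log units; beyond the scatter) from compound 3 to compound 4, 9.0-fold (0.95 log units) apart, beyond the scatter of two such steps. Read the other way, ethylamino in place of 2-chloroethyl on a carbonyl carbon gives an 8.1-fold lower number from compound 2 to compound 4 (0.91 log units; beyond the scatter) with iodo on the aromatic ring, but made no difference beyond the scatter with isopropyl there, so the two changes cannot be treated as separate contributions in this set: the same change on two cores in this assay, a 1.1-fold higher number (0.05 log units; within the scatter) from compound 1 to compound 3 and an 8.1-fold lower number (0.91 log units; beyond the scatter) from compound 2 to compound 4, 9.0-fold (0.95 log units) apart, beyond the scatter of two such steps. This shows that the gain appears only where iodo and ethylamino occur together among these four compounds; it does not show why, and a single square of compounds cannot establish a rule for the series.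

As far as these compounds go, it remains open whether bromo, chloro or methyl in place of isopropyl would pair with ethylamino as iodo does. From the compounds shown here alone, it is equally open whether a longer chain, such as propylamino, or a cyclic amine in place of ethylamino would keep the lower number.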